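The compounds below may be only part of what the source reports. "The series", "measured", "known", "first", "only" and "open" are said of these compounds alone.

Working notes, anilinoamidine series on the shared core of compound 3 `Cc1ccc(S(=O)(=O)/N=C(/CCNC2=CC(=O)c3ccccc3C2=O)Nc2ccc(F)cc2)cc1`. In a functional assay on DU-145 cells (Homo sapiens) for cytotoxicity, read by MTT assay, with a stated time of 48 h (a lower number here means a stronger inhibitor, a higher number a weaker inhibitor), compound 3 gives 12200 nM, second highest of the three numbers. Compound 1 `COc1ccc(N/C(CCNC2=CC(=O)c3ccccc3C2=O)=N\S(=O)(=O)c2ccc(C)cc2)cc1` gives 12000 nM in this assay, and the step of a 1.0-fold higher number from compound 1 to compound 3 (0.01 log units; within the scatter) sits within the scatter. Compound 2 `Cc1ccc(S(=O)(=O)/N=C(/CCNC2=CC(=O)c3ccccc3C2=O)Nc2ccc(Cl)cc2)cc1` gives 32400 nM in this assay; the step of a 2.7-fold lower number from compound 2 to compound 3 (0.42 log units; beyond the scatter) and the step of a 2.7-fold higher number from compound 1 to compound 2 (0.43 log units; beyond the scatter) are the only ones beyond the scatter, and both are modest. Compound 4 `Cc1ccc(S(=O)(=O)/N=C(/CCNC2=CC(=O)c3ccccc3C2=O)Nc2ccccc2[N+](=O)[O-])cc1` carries the change (2-nitrophenyl in place of 4-fluorophenyl on an amine nitrogen). Among the measured compounds shown here, no measured step covers a nitro group or this placement; the measured aryl swaps all stayed modest. Compound 4 is therefore expected to show a step of a 1.2-fold higher number from compound 3 to compound 4 (0.09 log units; within the scatter), estimated at 15000 nM, range 5000 nM to 50000 nM.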

Compound 4, half-maximal inhibitory concentration: 7590 nM
For compound 4 the middle estimate is 2.0-fold (0.30 log units) above the measured one, within the range that was stated.
By their numbers in this assay, from the lowest: compounds 4, 1 and 3 (each within the scatter of the next); then compound 2.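

In this assay the amine nitrogen accepts 2-nitrophenyl without leaving the range of the earlier aryl groups: a 1.6-fold lower number from compound 3 to compound 4 (0.21 log units; within the scatter) and a 1.6-fold lower number from compound 1 to compound 4 (0.20 log units; within the scatter) both sit within the scatter, and only a 4.3-fold lower number from compound 2 to compound 4 (0.63 log units; beyond the scatter) goes beyond it, modestly. The nitro-bearing ring therefore cannot be told apart from the fluoro and methoxy rings, and compound 2 alone stands apart from compound 4. Nothing available explains these steps. On these data alone, whether the nitro group or its placement matters stays open, as does whether an amine or a carboxylic acid on this ring would stay in the same range.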